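The source may hold more compounds than are shown below. What is called first, only, known or untested is meant among the compounds shown, and "the series" means these compounds.

Measured compounds:
compound 1 `Nc1ccc(C(=O)NO)cc1F` — 183 nM
compound 2 `Nc1ccc(C(=O)NO)cn1` — 240 nM
compound 3 `O=C(NO)c1cccnc1` — 679 nM

Of the compounds shown here, three have so far been measured in an assay on Sf9 cells for inhibition of protein deacetylase HDAC6 (Homo sapiens), read by fluorescence; on this read-out lower numbers stand for stronger inhibition and higher numbers for weaker inhibition. Compound 1 gives 183 nM, the lowest of the three numbers, but its gap to compound 2 lies within the scatter, so no order between these two can be read. Compound 3 stands furthest from compound 1, beyond the scatter. Among the compounds with values here, the only change that has been measured in isolation is the step of a 2.8-fold higher number from compound 2 to compound 3 (0.45 log units; beyond the scatter), hydrogen in place of amino on an aromatic carbon.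

Compound 4 `CC(=O)Nc1ccc(C(=O)NO)cc1F` has not yet been measured. It differs from compound 1 in a single place: acetyl in place of hydrogen on a nitrogen on an aromatic ring. Within the data shown here, no measured step covers this acetyl group. Among the measured compounds shown here, the one step that touches the same nitrogen, from compound 2 to compound 3, removed the amino group entirely and was modest, and compound 4 keeps the nitrogen in place. The expectation is therefore a small move, if any, and the direction is uncertain. Compound 4 is expected at about 230 nM, with a range from 90 nM to 600 nM. This estimate amounts to an expected step of a 1.3-fold higher number from compound 1 to compound 4 (0.10 log units; within the scatter).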

Compound 4, half-maximal inhibitory concentration: 58 nM
Estimate against measurement, compound 4: 4.0-fold (0.60 log units) above; measured number outside the range, below it.
By their numbers in this assay, from the lowest: compound 4; then compounds 1 and 2 (each within the scatter of the next); then compound 3.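

In this assay, within the data shown here, the change from amino to acetamido gives a 3.2-fold lower number from compound 1 to compound 4 (0.50 log units; beyond the scatter), a step beyond the scatter and the first measured change that keeps this nitrogen and adds to it. The earlier step, a 2.8-fold higher number from compound 2 to compound 3 (0.45 log units; beyond the scatter), showed only what follows when the amino group is replaced by hydrogen on another core, and it left unknown whether the nitrogen could carry anything larger; compound 4 shows that it can carry an acetyl group, and that the number then falls rather than rises. Nothing shown here gives a reason for this step, so the result stands as an observation about this one pair.

The compounds shown leave open whether the lower number belongs to the acetyl group itself or would also appear with another group on this nitrogen, such as a propionyl group, a benzoyl group or a simple methyl group. They also leave open whether the same acetyl group would give a step of similar size on the core of compound 2.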